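Changing the Amide Substituent of Compound 2

The compounds below may be only part of what the source reports. "The series", "measured", "known", "first", "only" and "open" are said of these compounds alone.

Compound 1: `COc1ccc(-c2cccc(C(=O)N(C)Cc3ccccc3)c2)cc1S(=O)(=O)Nc1cccc(NCCNC(=O)c2cccc(C)c2)c1` — 532 nM
Compound 2: `COc1ccc(-c2cccc(C(=O)NCc3ccccn3)c2)cc1S(=O)(=O)Nc1cccc(NCCNC(=O)c2cccc(C)c2)c1` — 464 nM

Of the compounds shown here, two with the shared core have been measured in a functional assay on CHO-RD-HGA16 cells for agonist activity at Orexin receptor type 2 (Homo sapiens), read by fluorescence and calcium flux, with a stated time of 30 min; a higher number here means that more compound is needed for the effect, a lower number that less compound is needed. Compound 1 gives 532 nM there, and compound 2 gives 464 nM. Compound 2 stands lowest of the two numbers, but only by a margin that falls inside the scatter: a 1.1-fold lower number from compound 1 to compound 2 (0.06 log units; within the scatter). Among the measured compounds shown here, the single measured step thus shows that the substituent on this carbonyl carbon can be exchanged without a change beyond the scatter.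

Compound 3, `COc1ccc(-c2cccc(C(=O)N(C)Cc3cccnc3)c2)cc1S(=O)(=O)Nc1cccc(NCCNC(=O)c2cccc(C)c2)c1`, carries the next exchange at the same place: methyl((pyridin-3-yl)methyl)amino in place of ((pyridin-2-yl)methyl)amino on a carbonyl carbon. For the measured compounds named here, the only step that bears on it is the one from compound 1 to compound 2, which was within the scatter, and compound 3 combines features of both neighbours, the methyl on the nitrogen of compound 1 and the pyridinylmethyl of compound 2. On that basis no step beyond the scatter is expected in this assay, and the estimated change is a 1.1-fold higher number from compound 2 to compound 3 (0.03 log units; within the scatter). Compound 3 is therefore expected to give about 500 nM, with a likely range from 200 nM to 1300 nM.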

Compound 3, half-maximal effective concentration: 134 nM
For compound 3 the middle estimate is 3.7-fold (0.57 log units) above the measured one; the measured number lies below the stated range.
By their numbers in this assay, from the lowest: compound 3; then compounds 2 and 1 (each within the scatter of the next).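

In this assay, among the compounds shown here, the substituent on this carbonyl carbon turns out to matter, for the single exchange of phenyl for pyridin-3-yl on a saturated chain carbon bound to an amide-type nitrogen gives a 4.0-fold lower number from compound 1 to compound 3 (0.60 log units; beyond the scatter) and so carries the number beyond the scatter, whereas the earlier step had stayed within it. The exchange of ((pyridin-2-yl)methyl)amino for methyl((pyridin-3-yl)methyl)amino gives a 3.5-fold lower number from compound 2 to compound 3 (0.54 log units; beyond the scatter) as a step of modest size, which shows that the two pyridine-bearing amides are not equivalent even though compound 2 and compound 1 could not be told apart. No measurement is at hand that would explain either step.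

The step to compound 3 changes the amide hydrogen to a methyl and moves the attachment on the pyridine ring in one exchange, so the shares of these two changes remain unresolved. Also open, going by these compounds, is how methyl((pyridin-2-yl)methyl)amino, ((pyridin-3-yl)methyl)amino or methyl((pyridin-4-yl)methyl)amino would fare on this carbonyl carbon in this assay and whether an ethyl could take the place of the methyl.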